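The source may report more compounds than this note shows. Statements on the series, on what has been measured and on what is new or still open speak of the compounds shown alone.

Measured so far:

compound 1 `CC(C)CCn1nc(C(=O)N[C@H]2COc3ccccc3N(C)C2=S)nc1Cc1ccccc1` — a toxicity assay on HT-29 cells (Homo sapiens) for cytotoxicity; a lower number here means that less compound is tolerated, a higher number that more compound is tolerated: > 100000 nM, a limit of the assay
compound 2 `CN1C(=S)[C@@H](NC(=O)c2nc(Cc3ccccc3)n(CCC(F)(F)F)n2)COc2ccccc21` — this assay: > 100000 nM, a limit of the assay

Compound 2 thus stands at the upper limit of this assay, with no number behind it. Going by the values given here, the one step available, a step that the two limits leave unreadable from compound 1 to compound 2, is the only comparison within the pair so far, and its size cannot be read, since both of its ends sit at the same limit (the limit of > 100000 nM in this assay, at which 2 of the 2 values shown sit).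

The next compound, compound 3 `CN1C(=S)[C@@H](NC(=O)c2nc(Cc3ccccc3)n(C3CCOC3)n2)COc2ccccc21`, differs from compound 2 by oxolan-3-yl in place of 3,3,3-trifluoropropyl on an aromatic nitrogen. Among the compounds with values here, the only measured step that bears on this position is the one from compound 1 to compound 2, and it gives no readable size; nothing else on the oxolan-3-yl group has been measured in this assay. The expectation therefore rests on where compound 2 stands: compound 3 is expected to come out near the limit as well, that is a number no higher from compound 2 to compound 3 (the limit leaves the size open), with no step beyond the scatter. Compound 3 is accordingly estimated at 100000 nM, in a range from 30000 nM to 300000 nM, most likely again reported only as a limit.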

Compound 3, half-maximal cytotoxic concentration: > 100000 nM
Compound 3: only a limit was reported; the forecaster's own chance of this, stated with the estimate: 80%; the middle value lies on the limit itself.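

No step can be read among compound 1, compound 2 and compound 3 in this assay, as all three values stand at a single limit: the limit of > 100000 nM in this assay, at which 3 of the 3 values shown sit.

The compounds shown leave open at what concentration any of the three reaches the half-maximal read-out, and whether isopentyl, 3,3,3-trifluoropropyl and oxolan-3-yl on the aromatic nitrogen differ at all.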